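A few compounds are considered here, and "the series" means these few. Any claim that something is new, unique, unknown or untested is made for them only; others in the source may bear on it.

For the measured compounds named here, compound 1 `CC1CCN(C2CCN(S(=O)(=O)c3cccc(-c4ccc(F)cc4)c3)CC2)CC1` was tested in a functional assay on DLD-1 cells (Homo sapiens) for antiproliferative activity, read by CellTiter-Glo, with a stated time of 72 h (on this read-out higher numbers stand for weaker inhibition and lower numbers for stronger inhibition), where compound 1 gives 12 nM, the only full number among the results so far. Compound 2 `CCCC(=O)N(Cc1ccccc1)C1CCN(S(=O)(=O)c2c(C)cc(C)cc2C)CC1` gives in this assay only a limit, > 5000 nM, not a number, which is the limit of > 5000 nM in this assay, at which 1 of the 2 values shown sits. Going by the values given here, compound 3 `Cc1cccc(S(=O)(=O)N2CCC(N3CCC(C)CC3)CC2)c1` differs from compound 1 in a single place: methyl in place of 4-fluorophenyl on an aromatic carbon No measured pair shows what such a change does, so the expectation rests on structure alone. The change is expected to weaken inhibition, a step of a 21-fold higher number from compound 1 to compound 3 (1.32 log units; beyond the scatter) beyond the usual scatter. Compound 3 is therefore estimated at 250 nM, within a range from 40 nM to 2500 nM.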

Compound 3, half-maximal inhibitory concentration: 25 nM
Estimate against measurement, compound 3: 10-fold (1.00 log units) above, outside the stated range (below it).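

At this position on the aromatic ring, swapping 4-fluorophenyl for methyl costs little in this assay: a 2.1-fold higher number from compound 1 to compound 3 (0.32 log units; beyond the scatter). Compound 3 still inhibits strongly, so a large aromatic group at this place is not needed for strong inhibition on this read-out. Nothing in the results shown accounts for the size of this step.

From the compounds shown here alone, it remains open how a plain hydrogen, an amine, a carboxylic acid or a longer alkyl chain would behave at this position. Going by these compounds, whether the step would hold with other changes to the shared core also remains open.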